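The source may hold more compounds than are shown below. What is called first, only, known or untested is meant among the compounds shown, and "the series" means these compounds.

Measured in a functional assay on A549 cells (Homo sapiens) for antiproliferative activity, read by sulforhodamine B assay, with a stated time of 48 h; on this read-out higher numbers stand for weaker inhibition of growth and lower numbers for stronger inhibition of growth:

- compound 1 `CC(C)CCc1c(OCCCCCCC(=O)NO)ccc2c1OC(=O)CC2`: > 30000 nM (a limit)
- compound 2 `CC(C)CCc1c(OCCCCCC(=O)NO)ccc2c1OC(=O)CC2`: > 30000 nM (a limit)
- compound 3 `CC(C)CCc1c(OCCCCC(=O)NO)ccc2c1OC(=O)CC2`: > 30000 nM (a limit)

Compound 3 stands at > 30000 nM, which is a limit of the assay and not a number. It is not alone there: the limit of > 30000 nM in this assay, at which 3 of the 3 values shown sit.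

The next compound, compound 4 `CC(C)CCc1c(OCCCCCCCC(=O)NO)ccc2c1OC(=O)CC2`, differs from compound 3 by 3-(hydroxycarbamoyl)propyl in place of hydroxycarbamoyl on a saturated chain carbon, four bonds along the chain from an oxygen on an aromatic ring. In words, 3-(hydroxycarbamoyl)propyl sits in place of hydroxycarbamoyl on a saturated chain carbon, four bonds along the chain from an oxygen on an aromatic ring.

Three measured steps change this same chain: a step that the two limits leave unreadable from compound 1 to compound 2, a step that the two limits leave unreadable from compound 2 to compound 3 and a step that the two limits leave unreadable from compound 1 to compound 3. All three join limit to limit, and no size can be read from them. On that basis, no step beyond the scatter is expected in this assay, and no direction can be named. The expected step is a number no higher from compound 3 to compound 4 (the limit leaves the size open). Another limit is the likeliest report. Compound 4 is estimated at about 30000 nM, with an expected range from 12000 nM to 60000 nM.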

Compound 4, concentration for 50% growth inhibition: > 30000 nM
Compound 4 gave a limit, no number (the forecaster's own chance of this, stated with the estimate: 85%); the middle value lies on the limit itself.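

In this assay compound 4 gives > 30000 nM, which is a limit of the assay and not a number. Its steps from compound 1, compound 2 and compound 3 cannot be read, since each joins one limit to another: the limit of > 30000 nM in this assay, at which 4 of the 4 values shown sit.

The compounds shown leave open how strongly any of them inhibits growth, and whether chain length matters at all.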